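The source may report more compounds than this note shows. Statements on the series, on what has been measured and on what is new or still open speak of the compounds shown alone.

In an ADME assay (liver) for metabolic stability, with Liver microsome (Rattus norvegicus) as the target, using microsomes and NADPH, with a stated time of 30 min, at 37 degrees C, tested at 1 uM (a lower number here means slower removal, a higher number faster removal of the compound), compound 2 `Nc1ccc(S(=O)(=O)c2ccc(-c3ccc(C(O)(C(F)(F)F)C(F)(F)F)cn3)cc2)cn1` gives < 14 mL.min-1.g-1 as a limit of the assay and not a number. Compound 1 `CC(O)(c1ccc(N2CCN(S(=O)(=O)c3ccc(N)nc3)CC2)cc1)C(F)(F)F` gives < 14 mL.min-1.g-1 as a limit too. Compound 3 `CC(O)(c1ccc(-c2ccc(S(=O)(=O)c3ccc(N)nc3)cn2)nc1)C(F)(F)F` also gives < 14 mL.min-1.g-1 as a limit. Compound 2 therefore stands with the other two, and no exact figure is available for any of them. Compound 4 `COCC#Cc1cc(C(O)(C(F)(F)F)C(F)(F)F)cnc1-c1ccc(S(=O)(=O)c2ccc(N)nc2)cc1` has 3-methoxyprop-1-yn-1-yl in place of hydrogen on an aromatic carbon, ortho to a large group: 3-methoxyprop-1-yn-1-yl in place of hydrogen on an aromatic carbon is the whole change. Among the compounds with values here, no measured step shows what such a change does here. A modest move toward faster removal is expected, with the estimated step of an at least 1.4-fold higher number from compound 2 to compound 4 (0.15 log units; that floor lies within the scatter) as its size. For compound 4 the estimated value in this assay is 20 mL.min-1.g-1 within an expected range of 10 mL.min-1.g-1 to 50 mL.min-1.g-1 and the assay may again report only a limit.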

Compound 4, intrinsic clearance in microsomes: > 399 mL.min-1.g-1
Compound 4: no number, only a limit; the forecaster's own chance of this, stated with the estimate: 45%; at least 19-fold (1.29 log units) between middle value and limit.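

In this assay, placing 3-methoxyprop-1-yn-1-yl on this aromatic carbon, ortho to a large group, gives an at least 28-fold higher number from compound 2 to compound 4 (1.45 log units; beyond the scatter). Both ends of this step are limits of the assay, so it gives only a floor for the true size. Compound 4 alone sits at the upper limit: the limit of > 399 mL.min-1.g-1 in this assay, at which 1 of the 4 values shown sits.

The compounds shown leave open whether the triple bond, the methoxy end or the whole chain goes with this step. A plain ethynyl group or an amine on the same carbon would help separate these possibilities.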